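Swapping the Amide Arm for a Methyl-Isoxazole

The source may report more compounds than this note shows. Statements on the series, on what has been measured and on what is new or still open speak of the compounds shown alone.

Measured so far:
compound 1 `CCN1CC(NC(=O)[C@@H]2CCCN(S(=O)(=O)c3ccc(S(=O)(=O)N(CC)CC)cc3)C2)C1` — > 30000 nM
compound 2 `CCN(CC)S(=O)(=O)c1ccc(S(=O)(=O)N2CCC[C@@H](C(=O)N[C@H]3CCN(C(=O)OC(C)(C)C)C3)C2)cc1` — 100 nM

In a functional assay on MIA PaCa-2 cells (Homo sapiens) for inhibition, read by MTT assay, with a stated time of 7 days (a lower number here means a stronger inhibitor, a higher number a weaker inhibitor), compound 1 gives only a limit, > 30000 nM, so its true value is not known. Within the data shown here, compound 2, which differs from it in the substituent on the amide-type nitrogen, gives 100 nM, and the step of an at least 300-fold lower number from compound 1 to compound 2 (2.47 log units; beyond the scatter) is the one measured comparison in this set.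

Compound 3 `CCN(CC)S(=O)(=O)c1ccc(S(=O)(=O)N2CCC[C@@H](c3cc(C)no3)C2)cc1` changes compound 1 at a different place: 3-methyl-1,2-oxazol-5-yl in place of (1-ethylazetidin-3-yl)carbamoyl on a saturated ring carbon. The whole carbamoyl arm is gone and a small aromatic ring takes its place. The measured step from compound 1 to compound 2 alters only the group on the amide-type nitrogen, so it bears on this change loosely: it shows that the shared core can reach strong inhibition once the azetidine arm is replaced, but not what a ring directly on the saturated carbon will do.

For compound 3 the step of an at least 3.7-fold lower number from compound 1 to compound 3 (0.57 log units; beyond the scatter) is expected, a gain that is uncertain because compound 1 sits at the limit of > 30000 nM in this assay, at which 1 of the 2 values shown sits. Compound 3 is therefore estimated at 8000 nM, with a range from 1000 nM to 30000 nM.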

Compound 3, half-maximal inhibitory concentration: 4900 nM
Estimate against measurement, compound 3: 1.6-fold (0.21 log units) above; the range from low to high includes it.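

In this assay the change gives an at least 6.1-fold lower number from compound 1 to compound 3 (0.78 log units; beyond the scatter) and so shows that this saturated ring carbon does not need the carbamoyl arm for measurable inhibition: a five-membered aromatic ring set directly on that carbon also gives it. Compound 2 gives 100 nM and compound 3 gives 4900 nM as its value, so the 3-methyl-1,2-oxazol-5-yl group does not reach the number of the best amide arm shown. The true size of the gain stays unknown because compound 1 stands at a limit: the limit of > 30000 nM in this assay, at which 1 of the 3 values shown sits.

As far as these compounds go, it remains open whether the methyl group on the new ring matters, and how an ethyl group in its place would compare. Also open, from the compounds shown here alone, is how a carboxylic acid or a simple amine would fare on this same saturated ring carbon.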